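The source may report more compounds than this note shows. Statements on the series, on what has been measured and on what is new or still open speak of the compounds shown alone.

Measured compounds in a functional assay on aorta with Alpha-1D adrenergic receptor (Rattus norvegicus) as the target; on this read-out higher numbers stand for an effect only at larger amounts of compound and lower numbers for an effect already at smaller amounts:

Compound 1 `CCn1nc(Cc2ccc(SC)cc2)c2ccccc2c1=O` gives > 100000 nM, which is a limit of this assay and not a number.
Compound 2 `COc1ccc(Cc2nn(-c3ccccc3)c(=O)c3ccccc23)cc1OC` gives > 100000 nM, also a limit of this assay.
Compound 3 `Cn1nc(Cc2ccc3ccccc3c2)c2ccccc2c1=O` gives > 10000 nM, again a limit of this assay.

Compound 1 thus stands at the limit of > 100000 nM in this assay, at which 2 of the 3 values shown sit, together with compound 2, while compound 3 sits at the limit of > 10000 nM in this assay, at which 1 of the 3 values shown sits. Within the data shown here, none of the three values is a number, so no measured step between them can be sized; all that the three show is that each lies at a limit of this assay.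

Compound 4 `CCCCn1nc(Cc2ccc(SC)cc2)c2ccccc2c1=O` has not been measured in this assay. It differs from compound 1 in one place: ethyl in place of hydrogen on a saturated chain carbon, two bonds along the chain from an aromatic nitrogen. Among the measured compounds shown here, no pair of measured compounds differs in this way, so no size can be read from the data for such a change. With compound 1 at a limit, the only available anchor is that limit, and the expectation is that the butyl chain of compound 4 leaves the picture where compound 1 stands, with the step of a number no higher from compound 1 to compound 4 (the limit leaves the size open) expected to be none beyond the scatter. Compound 4 is therefore expected to show 100000 nM in this assay, with a range from 20000 nM to 500000 nM, and most likely only a limit will again be reported.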

Compound 4, half-maximal effective concentration: > 100000 nM
Compound 4 ended at the assay's limit; the forecaster's own chance of this, stated with the estimate: 85%; the middle value sits exactly at the limit.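

Compound 1 and compound 4 both stand at a limit, and no step between them can be read in this assay: the limit of > 100000 nM in this assay, at which 3 of the 4 values shown sit.

The compounds shown leave open whether ethyl in place of hydrogen changes the effect at all, and at what concentration any of them would give a measurable effect.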